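The source may report more compounds than this note shows. Statements on the series, on what has been measured and on what is new or still open speak of the compounds shown alone.

Measured in a functional assay on U-937 cells (Homo sapiens) for cytotoxicity, read by MTT assay, with a stated time of 48 h; a lower number here means a stronger inhibitor, a higher number a weaker inhibitor:
- compound 1 `Fc1cccc(-c2nc(Nc3ccc(Cl)cc3)c3cc(F)ccc3n2)c1`: 32700 nM
- compound 2 `Cc1ccc(Nc2nc(-c3cccc(F)c3)nc3ccc(F)cc23)cc1`: > 50000 nM

Compound 2 gives > 50000 nM, which is a limit of the assay and not a number. It therefore has no exact place on the scale, and the limit is the limit of > 50000 nM in this assay, at which 1 of the 2 values shown sits.

The next compound, compound 3 `Cc1ccccc1Nc1nc(-c2cccc(F)c2)nc2ccc(F)cc12`, has the same atoms as compound 2, joined differently. It carries 2-methylphenyl in place of 4-methylphenyl on a nitrogen on an aromatic ring.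

Among the compounds with values here, only one measured step bears on this, and only loosely. It is an at least 1.5-fold higher number from compound 1 to compound 2 (0.18 log units; that floor lies within the scatter), which comes from methyl in place of chloro on an aromatic carbon. That step swaps a group rather than moving one, so no measurement here shows what moving the methyl does. With so little to go on, no change beyond the scatter is expected in this assay, in either direction.

The estimated step is a number no higher from compound 2 to compound 3 (the limit leaves the size open). The assay may well report only a limit again. For compound 3 the expected value is 50000 nM, with an estimated range from 25000 nM to 100000 nM.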

Compound 3, half-maximal inhibitory concentration: > 50000 nM
Compound 3: no number, only a limit; the forecaster's own chance of this, stated with the estimate: 60%; the middle value sits exactly at the limit.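

In this assay, compound 3 gives > 50000 nM, which is a limit of the assay and not a number. The effect of moving the methyl, from 4-methylphenyl to 2-methylphenyl, cannot be read, because compound 2 and compound 3 stand at the same limit: the limit of > 50000 nM in this assay, at which 2 of the 3 values shown sit. Set against the chloro compound, 2-methylphenyl in place of 4-chlorophenyl gives an at least 1.5-fold higher number from compound 1 to compound 3 (0.18 log units; that floor lies within the scatter), so no real difference can be claimed for this change either.

The compounds shown leave open whether moving the methyl alters the activity of the compound at all. They also leave open what a methoxy group or an amine in place of the methyl would give, and whether either would return a number rather than a limit.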